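Adding one methyl to the amide chain of compound 2

The source may report more compounds than this note shows. Statements on the series, on what has been measured and on what is new or still open speak of the compounds shown alone.

In a functional assay on BT-474 cells (Homo sapiens) for antiproliferative activity, read by sulforhodamine B assay, with a stated time of 4 days (a lower number here means a stronger inhibitor of growth, a higher number a weaker inhibitor of growth), compound 1 (`COc1cc(Cl)c(-c2nc(SCC(=O)NC(C)C)nc3[nH]cc(C#N)c23)cc1O`) gives 161 nM as its value, and compound 2 (`CCNC(=O)CSc1nc(-c2cc(OCC)c(OC)cc2Cl)c2c(C#N)c[nH]c2n1`) gives 44 nM as its value. Compound 2 thus holds the lower of the two numbers, and the gap between them lies beyond the usual scatter. Compound 3 (`CCOc1cc(-c2nc(SCC(=O)NC(C)C)nc3[nH]cc(C#N)c23)c(Cl)cc1OC`) has not yet been measured. It departs from compound 2 by a single change (methyl in place of hydrogen on a saturated chain carbon bound to an amide-type nitrogen and a saturated chain carbon): methyl in place of hydrogen on a saturated chain carbon bound to an amide-type nitrogen and a saturated chain carbon, which turns ethylcarbamoyl into isopropylcarbamoyl. Among the measured compounds shown here, no measured pair isolates this change, so nothing in the data fixes its size. In this assay a small step is expected, leaning toward a higher number, that is, a weaker inhibitor of growth, and probably not beyond the scatter. The estimate amounts to a 1.5-fold higher number from compound 2 to compound 3 (0.17 log units; within the scatter) as the expected step. In this assay the estimated value for compound 3 is 65 nM with an expected range from 25 nM to 170 nM for a measurement still to come.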

Compound 3, concentration for 50% growth inhibition: 84 nM
The estimate for compound 3 lay 1.3-fold (0.11 log units) below the measured number; the range from low to high includes it.
By their numbers in this assay, from the lowest: compounds 2, 3 and 1 (each within the scatter of the next, the first and the last beyond it).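

Among the compounds shown here, with compound 3, the change on the amide chain can be read on its own for the first time. In this assay, going from ethylcarbamoyl to isopropylcarbamoyl gives a step within the scatter (a 1.9-fold higher number from compound 2 to compound 3 (0.28 log units; within the scatter)), so at this saturated chain carbon the added methyl does not separate the two compounds, and the other step, ethyl in place of hydrogen on an oxygen on an aromatic ring, is also within the scatter (a 1.9-fold lower number from compound 1 to compound 3 (0.28 log units; within the scatter)). The earlier gap, which joined two changes in one comparison, thus falls into two single steps, neither beyond the scatter alone, and nothing available explains either step.

The compounds shown leave open how much further the amide chain can be altered before the number moves beyond the scatter, as a longer chain such as butyl, or a chain ending in an amine or a carboxylic acid, would show. Going by these compounds, it also remains open whether the methyl step reads the same when the ring oxygen carries hydrogen rather than ethyl.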